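Bromo to chloro at the limit of a growth assay

The source may report more compounds than this note shows. Statements on the series, on what has been measured and on what is new or still open speak of the compounds shown alone.

Compound 1 `N#Cc1ccc(/C=C/S(=O)(=O)Cc2ccc(Nc3ncnc4ccccc34)cc2)cc1`: > 100000 nM (a limit)
Compound 2 `O=S(=O)(/C=C/c1ccc(Cl)c(Cl)c1)Cc1ccc(Nc2ncnc3ccccc23)cc1`: 22000 nM
Compound 3 `O=S(=O)(/C=C/c1ccc(Br)cc1)Cc1ccc(Nc2ncnc3ccccc23)cc1`: > 100000 nM (a limit)

These values come from a functional assay on NCI/ADR-RES cells (Homo sapiens) for inhibition; on this read-out lower numbers stand for stronger inhibition of growth and higher numbers for weaker inhibition of growth. Compound 3 gives only a limit, > 100000 nM, and not a number. Its place on the scale is the limit of > 100000 nM in this assay, at which 2 of the 3 values shown sit.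

Compound 4 `O=S(=O)(/C=C/c1ccc(Cl)cc1)Cc1ccc(Nc2ncnc3ccccc23)cc1` differs from compound 3 in one place: chloro in place of bromo on an aromatic carbon. This swap sits para to a large group. For the measured compounds named here, no measured step makes this exact swap, so the estimate rests on neighbouring steps. The step at the same kind of carbon, a step that the two limits leave unreadable from compound 1 to compound 3, gives no size to work with. The other two steps are readable only in part: an at least 4.5-fold lower number from compound 1 to compound 2 (0.65 log units; beyond the scatter) and an at least 4.5-fold higher number from compound 2 to compound 3 (0.65 log units; beyond the scatter). Going by the values given here, both involve compound 2, the only compound here with a real number, 22000 nM. A modest step toward a lower number in this assay is therefore expected, although compound 4 may well stay at the limit. The expected change is an at least 1.6-fold lower number from compound 3 to compound 4 (0.22 log units; that floor lies within the scatter). For compound 4 the estimated value is 60000 nM, with an expected range from 20000 nM to 100000 nM.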

Compound 4, concentration for 50% growth inhibition: > 100000 nM
Compound 4 ended at the assay's limit; the forecaster's own chance of this, stated with the estimate: 50%; at least 1.6-fold (0.22 log units) between middle value and limit.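

In this assay compound 4 gives > 100000 nM, which is a limit and not a number. Compound 2 differs from compound 4 only in carrying a second chloro on the same ring, and replacing that chloro with hydrogen gives an at least 4.5-fold higher number from compound 2 to compound 4 (0.65 log units; beyond the scatter), so the growth inhibition seen for compound 2 does not survive with the 4-chlorophenyl group alone, and the second chloro matters in this small set. Bromo, chloro and nitrile at this para carbon cannot be put in any order, and the steps linking compound 1, compound 3 and compound 4 cannot be read, because all three rest on the same limit: the limit of > 100000 nM in this assay, at which 3 of the 4 values shown sit.

Going by these compounds, how far these three compounds lie beyond that limit remains unknown, so a real difference among them could still be hidden. On these data alone, it also remains open whether a methoxy group or an amine at this aromatic carbon, or a bromo in place of the second chloro of compound 2, would give a measurable number in this assay.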